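Extending the Amine Substituent on the Cyclopentane Core

The source may report more compounds than this note shows. Statements on the series, on what has been measured and on what is new or still open speak of the compounds shown alone.

The measured compounds are: compound 1 `CCC(=O)N(c1ccc(Cl)cc1)C1CCCCC1N(C)C` with 17 mg/kg; compound 2 `CCNC1CCCC1N(C(=O)CC)c1ccc(Cl)c(Cl)c1` with 2 mg/kg; compound 3 `C=CCNC1CCCC1N(C(=O)CC)c1ccc(Cl)c(Cl)c1` with 3 mg/kg.

In a functional assay on the whole organism for antagonist activity, with Mus musculus as the target (a higher number here means that more compound is needed for the effect, a lower number that less compound is needed), compound 3 stands second highest of the three numbers. Its nearest neighbour is compound 2, and the step of a 1.5-fold higher number from compound 2 to compound 3 (0.18 log units; within the scatter) lies within the scatter. Compound 1 sits furthest away, at a higher number, but it differs from compound 3 in more than one place, so only its value can be compared, not a single step.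

Compound 4 `CCCN(CCC)C1CCCC1N(C(=O)CC)c1ccc(Cl)c(Cl)c1` is not yet measured. It differs from compound 3 by dipropylamino in place of allylamino on a saturated ring carbon. Among the compounds with values here, the only step that touches the same position is a 1.5-fold higher number from compound 2 to compound 3 (0.18 log units; within the scatter), which was within the scatter, and it concerns a far smaller change than the present one. Within the data shown here, no measured step covers dipropylamino, so the expectation rests on weak ground. Because a 1.5-fold higher number from compound 2 to compound 3 (0.18 log units; within the scatter) was small, the writer expects a modest rise at most, with wide uncertainty. Compound 4 is estimated at 6 mg/kg, within 2 mg/kg to 20 mg/kg, which would mean a step of a 2.0-fold higher number from compound 3 to compound 4 (0.30 log units; within the scatter).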

Compound 4, dose for half-maximal effect: 0.1 mg/kg
Compound 4: the middle estimate sits 60-fold (1.78 log units) above what was measured; the whole stated range lies above it.
By their numbers in this assay, from the lowest: compound 4; then compounds 2 and 3 (each within the scatter of the next); then compound 1.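

In this assay, the earlier change at this saturated ring carbon had stayed within the scatter (a 1.5-fold higher number from compound 2 to compound 3 (0.18 log units; within the scatter)), whereas dipropylamino moves the number far more, with a 30-fold lower number from compound 3 to compound 4 (1.48 log units; beyond the scatter) and a 20-fold lower number from compound 2 to compound 4 (1.30 log units; beyond the scatter), so the position does respond strongly to the group it carries. The entering dipropylamino differs from both secondary amines in two ways at once, since it has two propyl chains on the nitrogen and 0 hydrogen-bond donors, and these compounds cannot separate the two changes. Nothing at hand accounts for the size of this step.

The compounds shown leave open whether a single propylamino group would give a similar number, which would separate chain length from the loss of the amine hydrogen. They also leave open how diethylamino or dibutylamino would compare at this position.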